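Shortening the phenoxy tether on a bicyclic EP2 agonist

This account rests on a few compounds, and the source may have more. Where it says the series, first, only, none or still open, it means among the compounds named here.

Measured compounds:
compound 1 `Cc1ccc(OC[C@@H]2[C@H]3CC[C@H](c4nc(C(=O)O)cs4)O[C@H]3C[C@H]2O)cc1`: 27 nM
compound 2 `O=C(O)c1csc([C@H]2CC[C@@H]3[C@@H](COc4cccc(Cl)c4)[C@H](O)C[C@@H]3O2)n1`: 6.5 nM
compound 3 `O=C(O)c1csc([C@H]2CC[C@@H]3[C@@H](CCCCCOc4ccccc4)[C@H](O)C[C@@H]3O2)n1`: 28 nM

In a functional assay on CHO cells for agonist activity at prostaglandin E2 receptor EP2 subtype (Homo sapiens), read by HTRF and cAMP accumulation, with a stated time of 30 min (on this read-out lower numbers stand for an effect already at smaller amounts and higher numbers for an effect only at larger amounts of compound), compound 3 gives 28 nM, the highest of the three numbers; compound 1 at 27 nM lies within the scatter of it, while compound 2 at 6.5 nM stands clearly lower. Compound 4 `O=C(O)c1csc([C@H]2CC[C@@H]3[C@@H](CCOc4ccccc4)[C@H](O)C[C@@H]3O2)n1` differs from compound 3 in one place: phenoxy in place of 3-phenoxypropyl on a saturated chain carbon, two bonds along the chain from a saturated ring carbon. Going by the values given here, the only step measured in one place, a 4.2-fold lower number from compound 1 to compound 2 (0.62 log units; beyond the scatter), concerns the aryl substituent and not the tether, so it does not bear directly on this change. Compound 1 and compound 3 differ in more than one place, yet their values lie within the scatter of each other, which gives no sign that the tether length moves the number. The step from compound 3 to compound 4 is therefore expected to stay within the scatter, a 1.1-fold lower number from compound 3 to compound 4 (0.05 log units; within the scatter), and compound 4 is estimated at 25 nM, with a range from 8 nM to 80 nM.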

Compound 4, half-maximal effective concentration: 1.4 nM
Estimate against measurement, compound 4: 18-fold (1.25 log units) above, and the stated range ends above it.
By their numbers in this assay, from the lowest: compound 4; then compound 2; then compounds 1 and 3 (each within the scatter of the next).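

In this assay, the change from 3-phenoxypropyl to phenoxy gives a 20-fold lower number from compound 3 to compound 4 (1.30 log units; beyond the scatter), so this position responds strongly to what sits on the chain, which the close values of compound 1 and compound 3 had not revealed. Phenoxymethyl in place of 3-chlorophenoxy gives a 4.6-fold lower number from compound 2 to compound 4 (0.67 log units; beyond the scatter), and phenoxymethyl in place of 4-methylphenoxy gives a 19-fold lower number from compound 1 to compound 4 (1.29 log units; beyond the scatter), but each of these replacements changes chain and ring substituent together, so the two effects stay unseparated. Nothing available explains why the number falls so far at this position.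

On these data alone, whether the 3-chlorophenyl ring of compound 2 would lower the number further on the chain of compound 4 remains open. So does the response of this position to a thioether or an amide in place of the chain oxygen.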